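Swapping methyl for chloro on the phenyl ring of compound 1

A few compounds are considered here, and "the series" means these few. Any claim that something is new, unique, unknown or untested is made for them only; others in the source may bear on it.

Measured so far:
compound 1, `Cc1ccc(C(C)NC(=O)/N=C(\N)NCCCc2sc(N)nc2C)cc1`: 30.9 nM
compound 2, `Cc1nc(N)sc1CCCN/C(N)=N/C(=O)NCc1ccccc1`: 69.2 nM

Both compounds were tested in an assay on membranes from Sf9 cells for displacement of a labelled ligand from histamine H2 receptor (Homo sapiens), read by scintillation counting, with a stated time of 60 min; a lower number here means a stronger inhibitor, a higher number a weaker inhibitor. Compound 1 gives 30.9 nM, the lower of the two numbers; compound 2 gives 69.2 nM, and the gap between them lies beyond the usual scatter, so compound 1 is the stronger binder of the pair.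

Compound 3, `Cc1nc(N)sc1CCCN/C(N)=N/C(=O)NC(C)c1ccc(Cl)cc1`, has not yet been measured. It differs from compound 1 in a single spot: chloro in place of methyl on an aromatic carbon. Cut one bond further out, the change reads 4-methylphenyl to 4-chlorophenyl. Among the compounds with values here, no measured pair shows what such a swap does here, so there is no step to lean on.

With only two data points and no comparable swap, the expectation is a step from compound 1 to compound 3 of a 1.0-fold lower number from compound 1 to compound 3 (0.01 log units; within the scatter), that is, no change beyond the scatter. Compound 3 is therefore estimated at 30 nM, with a range from 12 nM to 80 nM.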

Compound 3, inhibition constant: 46.8 nM
The estimate for compound 3 lay 1.6-fold (0.19 log units) below the measured number; low and high end bracket the measured number.
By their numbers in this assay, from the lowest: compounds 1, 3 and 2 (each within the scatter of the next, the first and the last beyond it).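

In this assay, within the data shown here, this is a first reading of the position on the phenyl ring: chloro in place of methyl on an aromatic carbon, para to a large group, gives a 1.5-fold higher number from compound 1 to compound 3 (0.18 log units; within the scatter) and so the two groups cannot be told apart here. Methyl and chloro each count one heavy atom and neither carries a hydrogen-bond donor or acceptor, so this pair speaks only for a swap of that kind. Nothing at hand offers an explanation for how these two groups compare.

As far as these compounds go, whether the same position would tolerate a hydroxyl, a methoxy or a carboxylic acid remains open. So does what a bulkier group such as tert-butyl would do there, and whether chloro would read the same at another place on the ring.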